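The source may report more compounds than this note shows. Statements on the series, on what has been measured and on what is new or still open speak of the compounds shown alone.

Measured compounds: compound 1 `Cc1ccc(-c2cc(/N=C3/NC(=O)CS3)cs2)cc1` gives > 50000 nM in a functional assay on HT-29 cells (Homo sapiens) for cytotoxicity, read by MTT assay, with a stated time of 72 h (a higher number here means a weaker inhibitor, a lower number a stronger inhibitor), which is a limit of the assay and not a number. Compound 2 `O=C1CS/C(=N\c2csc(-c3ccc(Cl)cc3)c2)N1` gives 17100 nM.

Compound 1 thus stands only at the limit (the limit of > 50000 nM in this assay, at which 1 of the 2 values shown sits), with no number of its own. Compound 3 `COc1cccc(N2C(=O)CS/C2=N\c2csc(-c3ccc(C)cc3)c2)c1` differs from compound 1 by 3-methoxyphenyl in place of hydrogen on an amide-type nitrogen in a ring. Among the compounds with values here, the single measured step, an at least 2.9-fold lower number from compound 1 to compound 2 (0.46 log units; beyond the scatter), alters a substituent on an aromatic carbon and leaves the amide nitrogen untouched, so it does not bear on this change. Without a guide, compound 3 is expected near 30000 nM, between 8000 nM and 100000 nM. The expected step is an at least 1.6-fold lower number from compound 1 to compound 3 (0.22 log units; that floor lies within the scatter).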

Compound 3, half-maximal inhibitory concentration: > 50000 nM
Compound 3: only a limit was reported (the forecaster's own chance of this, stated with the estimate: 50%); middle value at least 1.6-fold (0.22 log units) away from the limit.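

Compound 3, like compound 1, stands only at a limit of the assay, so the step between them cannot be read. The compounds shown leave open whether 3-methoxyphenyl on the amide-type nitrogen raises or lowers the number at all.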